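Removing the fluoro group from compound 2

The source may hold more compounds than are shown below. What is called first, only, known or untested is meant among the compounds shown, and "the series" means these compounds.

Of the compounds shown here, three sharing one core have been measured so far in an ADME assay on A549 cells (Homo sapiens) for cytotoxicity, read by resazurin assay, with a stated time of 48 h (a higher number here means that more compound is tolerated, a lower number that less compound is tolerated), for their half-maximal cytotoxic concentration. There compound 1 (`O=C(Nc1ccc([N+](=O)[O-])c(Cl)c1)c1cc(Cl)ccc1O`) gives 15100 nM in this test, compound 2 (`O=C(Nc1ccc([N+](=O)[O-])cc1F)c1cc(Cl)ccc1O`) gives 10900 nM and compound 3 (`O=C(Nc1cc([N+](=O)[O-])ccc1F)c1cc(Cl)ccc1O`) gives 8100 nM under the same conditions. Compound 2 stands among values that all lie within the scatter of one another, nearest to compound 3 and furthest from compound 1, so no ranking can be drawn.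

The next step leads to compound 4 (`O=C(Nc1ccc([N+](=O)[O-])cc1)c1cc(Cl)ccc1O`), in which hydrogen takes the place of fluoro on an aromatic carbon (hydrogen in place of fluoro on an aromatic carbon). Going by the values given here, no measured pair isolates a change of this kind, so the evidence is indirect. Compound 1 and compound 3 stay within the scatter of compound 2 at 10900 nM despite their structural differences. No step beyond the scatter is therefore expected in this assay and no direction is favoured. The estimated 1.1-fold lower number from compound 2 to compound 4 (0.04 log units; within the scatter) is small. Compound 4 is expected at 10000 nM within an estimated range of 4500 nM to 22000 nM when measured.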

Compound 4, half-maximal cytotoxic concentration: 27100 nM
Beside the measured number, compound 4's estimate is 2.7-fold (0.43 log units) below it; the measured number lies above the stated range.
By their numbers in this assay, from the lowest: compounds 3, 2, 1 and 4 (each within the scatter of the next, the first and the last beyond it).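

Going by these compounds alone, the step at this position is the first to clear the scatter: in this assay, hydrogen in place of fluoro on the aromatic carbon ortho to a large group and meta to a nitro group gives a 2.5-fold higher number from compound 2 to compound 4 (0.40 log units; beyond the scatter), a modest change that the earlier compounds, all within the scatter of one another, could not reveal. Hydrogen in place of chloro gives a 1.8-fold higher number from compound 1 to compound 4 (0.25 log units; within the scatter), so only the loss of fluoro stands clear of the scatter, and the two replacements do not read alike. Nothing given here accounts for the step at the fluoro position.

The compounds shown leave open how a methyl group, a methoxy group or an amine on this same carbon would compare with fluoro and hydrogen. They also leave open whether losing fluoro from compound 3 would give a step like the one seen here.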